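A few compounds are considered here, and "the series" means these few. Any claim that something is new, unique, unknown or untested is made for them only; others in the source may bear on it.

Compound 1 `Cc1nnc(Sc2cc(NC(=O)c3ccc(Cl)cc3)c3ccccc3c2O)s1`: 8.48%
Compound 2 `O=C(Nc1cc(Sc2nncs2)c(O)c2ccccc12)c1ccc(Cl)cc1`: 7.5%
Compound 3 `O=C(Nc1cc(Sc2ncn[nH]2)c(O)c2ccccc12)c1ccc(Cl)cc1`: 50.1%

All three were tested in an assay on isolated protein for inhibition of RAC-alpha serine/threonine-protein kinase (Homo sapiens), read by fluorescence, with a stated time of 30 min, tested at 10 uM; a higher number here means more inhibition at the concentration tested (going by the name of the read-out), a lower number less inhibition. Compound 3 stands highest of the three numbers; the nearest step up to it is a number 41.6 percentage points higher from compound 1 to compound 3 (beyond the scatter) and the furthest is a number 42.6 percentage points higher from compound 2 to compound 3 (beyond the scatter). The remaining step, a number 1 percentage points lower from compound 1 to compound 2 (within the scatter), lies within the scatter. Compound 4 `Cn1nnnc1Sc1cc(NC(=O)c2ccc(Cl)cc2)c2ccccc2c1O` has not yet been measured; it differs from compound 3 in one place: 1-methyl-1H-tetrazol-5-yl in place of 1H-1,2,4-triazol-5-yl on a sulfur. Both large steps seen so far changed the group on that same sulfur, so another change there is expected to give a large step in this assay, this time downward: a number 38.1 percentage points lower from compound 3 to compound 4 (beyond the scatter). Compound 4 is therefore estimated at 12%, expected between 3% and 35%.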

Compound 4, a percentage reported as inhibition, at one concentration (the size of the read-out at that concentration, not a potency): 13.1%
For compound 4 the middle estimate is 1.1 percentage points below the measured one, within the range that was stated.
By their numbers in this assay, from the lowest: compounds 2, 1 and 4 (each within the scatter of the next); then compound 3.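

A ring with more nitrogen does not keep the gain on this sulfur (a number 37 percentage points lower from compound 3 to compound 4 (beyond the scatter)), and compound 4 instead sits with the two thiadiazole compounds (a number 5.6 percentage points higher from compound 2 to compound 4 (within the scatter); a number 4.6 percentage points higher from compound 1 to compound 4 (within the scatter)). Among these four compounds, only the 1H-1,2,4-triazol-5-yl stands apart. No measurement here explains why. This change swaps the ring, adds a methyl and removes the hydrogen-bond donor all at once, so the compounds shown cannot separate these effects. A 1H-tetrazol-5-yl on the same sulfur would test the methyl and donor apart from the ring.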